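Two measured neighbours and one unmeasured chain

The source may report more compounds than this note shows. Statements on the series, on what has been measured and on what is new or still open speak of the compounds shown alone.

Compound 1 `CCCCCCn1cnc2c(Nc3cccc(Cl)c3)nc(N[C@H]3CC[C@H](N)CC3)nc21` gives 2300 nM
Compound 2 `N[C@H]1CC[C@H](Nc2nc(Nc3cccc(Cl)c3)c3ncn(Cc4ccccc4)c3n2)CC1` gives 3000 nM

In a functional assay on K562 cells (Homo sapiens) for inhibition, read by fluorescence, with a stated time of 72 h (a higher number here means a weaker inhibitor of growth, a lower number a stronger inhibitor of growth), compound 2 stands at 3000 nM and lies within the usual scatter of compound 1, so the two cannot be ranked. Compound 3 `CC(C)=CCC/C(C)=C/Cn1cnc2c(Nc3cccc(Cl)c3)nc(N[C@H]3CC[C@H](N)CC3)nc21` has not yet been measured. Its change from compound 2 is 2,6-dimethylhepta-1,5-dien-1-yl in place of phenyl on a saturated chain carbon bound to an aromatic nitrogen and, seen one bond further out, benzyl gives way to 3,7-dimethylocta-2,6-dien-1-yl. Among the compounds with values here, the only measured step at this place is a 1.3-fold higher number from compound 1 to compound 2 (0.12 log units; within the scatter) with phenyl in place of pentyl, so no shift beyond the scatter is expected in this assay in either direction. Still, no chain with double bonds has been measured, which leaves this expectation loosely supported. The expected step is a 1.2-fold lower number from compound 2 to compound 3 (0.08 log units; within the scatter) as a rough estimate. For compound 3 the estimated value is 2500 nM with an expected range from 800 nM to 7500 nM for now.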

Compound 3, concentration for 50% growth inhibition: 2200 nM
Compound 3: the middle estimate sits 1.1-fold (0.06 log units) above what was measured, within the range that was stated.
By their numbers in this assay, from the lowest: compounds 3, 1 and 2 (each within the scatter of the next).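

In this assay this place, on a saturated chain carbon bound to an aromatic nitrogen, now also carries 2,6-dimethylhepta-1,5-dien-1-yl, an open group with no ring and 2 double bonds, and both new steps stay within the scatter (a 1.4-fold lower number from compound 2 to compound 3 (0.13 log units; within the scatter); a 1.0-fold lower number from compound 1 to compound 3 (0.02 log units; within the scatter)). Pentyl, phenyl and this larger group of 9 heavy atoms therefore cannot be ranked, so among these three compounds neither the ring nor the double bonds separates one from another. Nothing measured here explains why the three read alike.

From the compounds shown here alone, all three groups contain only carbon and hydrogen, so a chain ending in an amine or a carboxylic acid remains open, as does a small group such as methyl. Whether any of these would move the number in this assay beyond the scatter cannot be told from these compounds.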